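Fluoro in place of hydrogen: compound 4 in the series

This account rests on a few compounds, and the source may have more. Where it says the series, first, only, none or still open, it means among the compounds named here.

Compound 1 `O=C1O/C(=C\Cn2ccc(=O)[nH]c2=O)C(OCc2ccccc2)=C1OCc1ccccc1` is the parent. In a functional assay on CCRF-CEM cells (Homo sapiens) for inhibition (a higher number here means a weaker inhibitor, a lower number a stronger inhibitor), compound 1 gives 13000 nM, the highest number of the three measured; its nearest neighbour is compound 3 and the furthest compound 2. Compound 2 `O=C1O/C(=C\Cn2cc(Br)c(=O)[nH]c2=O)C(OCc2ccccc2)=C1OCc1ccccc1` carries bromo in place of hydrogen on an aromatic carbon, and in this assay compound 2 gives 3500 nM. Compound 3 `O=C1O/C(=C\Cn2cc(Cl)c(=O)[nH]c2=O)C(OCc2ccccc2)=C1OCc1ccccc1` carries chloro in place of hydrogen on an aromatic carbon, and in this assay compound 3 gives 6000 nM. The change to compound 4 `O=C1O/C(=C\Cn2cc(F)c(=O)[nH]c2=O)C(OCc2ccccc2)=C1OCc1ccccc1` is fluoro in place of hydrogen on an aromatic carbon. Among the measured compounds shown here, two measured steps bear on it: a 3.7-fold lower number from compound 1 to compound 2 (0.57 log units; beyond the scatter) and a 2.2-fold lower number from compound 1 to compound 3 (0.34 log units; beyond the scatter). Between the two halogens, a 1.7-fold higher number from compound 2 to compound 3 (0.23 log units; within the scatter), so they do not separate. Fluoro is the smallest of the three halogens, and the two measured steps were only modest. A lowering of the number is therefore expected for compound 4 in this assay, but a smaller one than either measured step, near the edge of the scatter. The estimate for compound 4 is 8000 nM (range 4000 nM to 16000 nM), which means a 1.6-fold lower number from compound 1 to compound 4 (0.21 log units; within the scatter) is expected.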

Compound 4, half-maximal inhibitory concentration: 15100 nM
Compound 4: middle estimate off by 1.9-fold (0.28 log units), on the low side; low and high end bracket the measured number.
By their numbers in this assay, from the lowest: compounds 2 and 3 (each within the scatter of the next); then compounds 1 and 4 (each within the scatter of the next).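

In this assay, a halogen on this aromatic carbon does not by itself lower the number: fluoro in place of hydrogen gives a 1.2-fold higher number from compound 1 to compound 4 (0.07 log units; within the scatter), leaving compound 4 within the scatter of the parent. The halogens now separate, with fluoro in place of chloro giving a 2.5-fold higher number from compound 3 to compound 4 (0.40 log units; beyond the scatter) and fluoro in place of bromo giving a 4.3-fold higher number from compound 2 to compound 4 (0.63 log units; beyond the scatter), so the lowering seen with bromo and chloro does not extend to fluoro. No measurement at hand explains this difference among the halogens.

On these data alone, whether a non-halogen group on this carbon, such as methyl, an amine or a nitrile, would lower the number remains open. Also open, as far as these compounds go, is whether the step from hydrogen to bromo would hold with other groups elsewhere on the shared core.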